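Swapping Ethoxy for Pyrrolidinyl: Expected Lipophilicity Shift

The source may hold more compounds than are shown below. What is called first, only, known or untested is meant among the compounds shown, and "the series" means these compounds.

Of the compounds shown here, two with a shared core have been measured in a physicochemical assay for lipophilicity; a higher number here means a more lipophilic compound, a lower number a more polar compound. Compound 1, `CCOc1ccc(Cl)c(C(=O)NC(=O)Nc2nc3ccc(S(=O)(=O)CCCN4CCN(C)CC4)cc3s2)c1`, gives 2.4 in this assay. Compound 2, `CCN(CC)CCCS(=O)(=O)c1ccc2nc(NC(=O)NC(=O)c3cc(-n4cccn4)ccc3Cl)sc2c1`, gives 2.1 in this assay. Going by the values given here, the two values lie within the usual scatter of each other, so compound 1 cannot be set apart from compound 2 on these numbers; it simply stands at the same level as the only other measured compound.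

Compound 3, `CN1CCN(CCCS(=O)(=O)c2ccc3nc(NC(=O)NC(=O)c4cc(N5CCCC5)ccc4Cl)sc3c2)CC1`, has not yet been measured in this assay. It differs from compound 1 in one place: pyrrolidin-1-yl in place of ethoxy on an aromatic carbon. Among the compounds with values here, no pair of measured compounds shows this same change, so no measured step guides the expectation.

A step of moderate size toward a higher number, beyond the scatter, is expected for the change from compound 1 to compound 3, with a number 0.50 log units higher from compound 1 to compound 3 (beyond the scatter) as the expected size. Compound 3 is therefore estimated to give 2.9 in this assay, within a range from 2.4 to 3.4.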

Compound 3, distribution coefficient: 3.1
For compound 3 the middle estimate is 0.20 log units below the measured one; the range from low to high includes it.
By their numbers in this assay, from the lowest: compounds 2 and 1 (each within the scatter of the next); then compound 3.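

Going by these compounds alone, replacing ethoxy with pyrrolidin-1-yl on this aromatic carbon, para to the chloro group, gives the first measured step at this position in this assay, with a number 0.70 log units higher from compound 1 to compound 3 (beyond the scatter) as its size. This place therefore responds to the group it carries, even though both groups count no hydrogen-bond donors, one hydrogen-bond acceptor and no net charge. Nothing in hand explains the step, so the share of the ring, the extra carbons or the nitrogen in place of oxygen remains unknown.

The compounds shown leave open how other groups would read at this carbon, such as dimethylamino, an open-chain amine, or piperidin-1-yl, a six-membered ring. They also leave open whether the same swap would give a similar step with a different chain on the far side of the molecule.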